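A few compounds are considered here, and "the series" means these few. Any claim that something is new, unique, unknown or untested is made for them only; others in the source may bear on it.

Measured in a functional assay on the whole organism with Cavia porcellus as the target; on this read-out higher numbers stand for an effect only at larger amounts of compound and lower numbers for an effect already at smaller amounts:
- Compound 1 `COc1cc(C(=O)NS(=O)(=O)c2ccccc2C)ccc1Cc1cn(C)c2ccc(C(=O)NCC(C)C)cc12`: > 30 umol/kg, a limit of the assay
- Compound 2 `CCC(CC)CNC(=O)c1ccc2c(c1)c(Cc1ccc(C(=O)NS(=O)(=O)c3ccccc3C)cc1OC)cn2CC`: 5.3 umol/kg

For the measured compounds named here, compound 2 holds the only actual number so far, as the one other result is a limit. Compound 3 `CCC(CC)CNC(=O)c1ccc2c(c1)c(Cc1ccc(C(=O)NS(=O)(=O)c3ccccc3C)cc1OC)cn2C(C)C` is not yet measured. It carries methyl in place of hydrogen on a saturated chain carbon bound to an aromatic nitrogen and a saturated chain carbon, which turns ethyl to isopropyl. Going by the values given here, no measured step bears on this change, so the direction stays open. The expected step is a 1.0-fold higher number from compound 2 to compound 3 (0.02 log units; within the scatter), none beyond the scatter. In this assay, compound 3 is estimated at 5.5 umol/kg, with an expected range of 2 umol/kg to 15 umol/kg.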

Compound 3, dose for half-maximal effect: 4.7 umol/kg
Beside the measured number, compound 3's estimate is 1.2-fold (0.07 log units) above it; the range from low to high includes it.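

In this assay, ethyl to isopropyl, with methyl in place of hydrogen on a saturated chain carbon bound to an aromatic nitrogen and a saturated chain carbon, gives a 1.1-fold lower number from compound 2 to compound 3 (0.05 log units; within the scatter) as the first step read at this position. The position therefore takes this added methyl with no shift beyond the scatter. No measurement at hand accounts for this step.

From the compounds shown here alone, whether a longer chain such as butyl, a cyclopropyl or a chain ending in a carboxylic acid would hold the number at this position stays open. Compound 1 gives only a limit and differs from compound 2 in more than one place, so no single change can be read from it.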